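The source may report more compounds than this note shows. Statements on the series, on what has been measured and on what is new or still open speak of the compounds shown alone.

Measured compounds:
Compound 1, `NC(=O)c1cn([C@@H]2O[C@H](CO)[C@@H](O)[C@H]2O)nn1`: in a functional assay on L1210 cells (Mus musculus) (on this read-out lower numbers stand for stronger inhibition and higher numbers for weaker inhibition), compound 1 gives > 200000 nM, which is a limit of the assay and not a number.
Compound 2, `CC(O)c1cn([C@@H]2O[C@H](CO)[C@@H](O)[C@H]2O)nn1`: in this assay compound 2 gives > 200000 nM, again only a limit.

Compound 2 therefore stands at the limit of > 200000 nM in this assay, at which 2 of the 2 values shown sit. Among the measured compounds shown here, the only measured step, a step that the two limits leave unreadable from compound 1 to compound 2, is unreadable, so nothing here shows how large a change on that aromatic carbon can be. Compound 3, `OC[C@H]1O[C@@H](n2cc(-c3ccsc3)nn2)[C@H](O)[C@@H]1O`, differs from compound 2 by thiophen-3-yl in place of 1-hydroxyethyl on an aromatic carbon. With no readable step to lean on, the expected step in this assay is an at least 1.3-fold lower number from compound 2 to compound 3 (0.12 log units; that floor lies within the scatter), and the estimate for compound 3 is 150000 nM (from 20000 nM to 400000 nM).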

Compound 3, half-maximal inhibitory concentration: 182000 nM
Estimate against measurement, compound 3: 1.2-fold (0.08 log units) below; low and high end bracket the measured number.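

In this assay, among the compounds shown here, compound 3 gives 182000 nM as the first value at this position that is a number and not a limit. Thiophen-3-yl in place of 1-hydroxyethyl is an at least 1.0-fold lower number from compound 2 to compound 3 (0.04 log units; that floor lies within the scatter) and thiophen-3-yl in place of carbamoyl is an at least 1.0-fold lower number from compound 1 to compound 3 (0.04 log units; that floor lies within the scatter) as far as the limits allow a reading. Neither floor goes beyond the scatter, so thiophen-3-yl is not shown to outperform either earlier group. Still open is whether an amine or a longer chain here would give a lower number, and how far the real values of compound 1 and compound 2 lie past their limit: the limit of > 200000 nM in this assay, at which 2 of the 3 values shown sit.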